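Benzyl ether in place of trifluoromethyl ether on the shared core

A few compounds are considered here, and "the series" means these few. Any claim that something is new, unique, unknown or untested is made for them only; others in the source may bear on it.

Compound 1, `Cc1cc(C)cc(NC(=O)COc2cc(C)nc3ccc(C)cc23)c1`: 15900 nM
Compound 2, `Cc1cc(C)cc(NC(=O)COc2cc(C)nc3ccc(OC(F)(F)F)cc23)c1`: > 100000 nM

Both numbers come from a toxicity assay on HepG2 cells (Homo sapiens) for inhibition, read by CellTiter-Glo, with a stated time of 48 h; a higher number here means a weaker inhibitor, a lower number a stronger inhibitor. Compound 1 gives 15900 nM there. Compound 2 gives only a limit in this assay, > 100000 nM, so its standing is known as a bound and not as a number, as the evidence shows (the limit of > 100000 nM in this assay, at which 1 of the 2 values shown sits). Within the data shown here, the single measured step, an at least 6.2-fold higher number from compound 1 to compound 2 (0.79 log units; beyond the scatter), runs in the weakening direction.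

Compound 3, `Cc1cc(C)cc(NC(=O)COc2cc(C)nc3ccc(OCc4ccccc4)cc23)c1`, differs from compound 2 by benzyl in place of trifluoromethyl on an oxygen on an aromatic ring. Among the measured compounds shown here, no measured step covers this change, so the step from compound 1 to compound 2 gives only a rough guide. The account expects compound 3 to move back toward a measurable number, with an estimated step of an at least 2.5-fold lower number from compound 2 to compound 3 (0.39 log units; beyond the scatter). Compound 3 is therefore estimated at 40000 nM in this assay, within 8000 nM to 150000 nM.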

Compound 3, half-maximal inhibitory concentration: > 100000 nM
Compound 3 gave a limit, no number (the forecaster's own chance of this, stated with the estimate: 40%); at least 2.5-fold (0.39 log units) between middle value and limit.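

In this assay compound 3 gives only a limit, > 100000 nM, so benzyl in place of trifluoromethyl on this oxygen does not restore a measurable number. Benzyloxy in place of methyl on this aromatic carbon gives an at least 6.2-fold higher number from compound 1 to compound 3 (0.79 log units; beyond the scatter), so a second group attached through oxygen now shares the direction first seen with trifluoromethoxy. The step from compound 2 to compound 3 cannot be read, and the shared core with either of these two groups stays at the ceiling of the assay: the limit of > 100000 nM in this assay, at which 2 of the 3 values shown sit.

As far as these compounds go, whether compound 2 and compound 3 truly differ in this assay remains open, as does how far past the limit each one lies. Also open, from the compounds shown here alone, is how an amine or a carboxylic acid at this place would read, and whether a plain methoxy group would stay measurable.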